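This account rests on a few compounds, and the source may have more. Where it says the series, first, only, none or still open, it means among the compounds named here.

The measured compounds:

compound 1, `Nc1nc(-c2ccc(F)cc2)cc(-c2ccccc2O)n1`: 67500 nM
compound 2, `COc1cccc(-c2cc(-c3ccccc3O)nc(N)n2)c1`: a limit, > 78300 nM

For the measured compounds named here, compound 1 stands as the only compound with a number in an ADME assay on MT4 cells (Homo sapiens) for cytotoxicity, read by MTT assay, with a stated time of 5 days (a higher number here means that more compound is tolerated, a lower number that less compound is tolerated), where compound 1 gives 67500 nM. Compound 2 is a different case in this assay: compound 2 reaches only a limit, > 78300 nM, and this is the limit of > 78300 nM in this assay, at which 1 of the 2 values shown sits. So the two values do not give a step to compare; one is a number and the other is a limit, and nothing more can be read from the pair.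

Compound 3, `Nc1nc(-c2ccco2)cc(-c2ccccc2O)n1`, differs from compound 1 in one place: furan-2-yl in place of 4-fluorophenyl on an aromatic carbon. Going by the values given here, no measured step exists that could anchor this change. The account therefore expects the step from compound 1 to compound 3 to stay within the usual scatter, with a 1.0-fold higher number from compound 1 to compound 3 (0.02 log units; within the scatter) as the expected move, in no clear direction. Compound 3 is estimated to give 70000 nM in this assay, with a range from 30000 nM to 160000 nM, and there is a fair chance that only a limit is reported.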

Compound 3, half-maximal cytotoxic concentration: > 125000 nM
Compound 3: a limit, no number; the forecaster's own chance of this, stated with the estimate: 40%; at least 1.7-fold (0.25 log units) between middle value and limit.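

In this assay, for the compounds shown here, furan-2-yl in place of 4-fluorophenyl on this aromatic carbon gives the first step that can be read at this position: an at least 1.8-fold higher number from compound 1 to compound 3 (0.26 log units; that floor lies within the scatter). Since that floor lies within the scatter, the step does not establish a real gain; it shows only that this aromatic carbon can carry a five-membered aromatic ring with 1 hetero atom in place of a six-membered aromatic ring of carbon only, with no fall in the number tolerated. Compound 3 gives a limit and not a number, so the step has a floor but no upper end: the limit of > 125000 nM in this assay, at which 1 of the 3 values shown sits.

The compounds shown leave open how large the step from 4-fluorophenyl to furan-2-yl really is, and any step involving the limit of compound 2 cannot be read. They also leave open how this assay would respond to an amine, a carboxylic acid or a longer chain on this aromatic carbon, and to any change to the 2-hydroxyphenyl group or the amino group.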